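From phenylsulfanyl to methylsulfonyl on the shared core

This account rests on a few compounds, and the source may have more. Where it says the series, first, only, none or still open, it means among the compounds named here.

Compound 1 `CCN(CC)CCNC(=O)c1ccc(C(CC)(CC)c2ccc(OCS(=O)(=O)c3ccccc3)c(C)c2)n1CC` gives 4680 nM in this series
Compound 2 `CCN(CC)CCNC(=O)c1ccc(C(CC)(CC)c2ccc(OCSc3ccccc3)c(C)c2)n1CC` gives 4900 nM in this series

Among the measured compounds shown here, in a functional assay on MCF7 cells (Homo sapiens) for antiproliferative activity, read by MTT assay, with a stated time of 24 h (on this read-out higher numbers stand for weaker inhibition and lower numbers for stronger inhibition), compound 2 stands level with compound 1, the only other measured compound, and the two values cannot be told apart. Compound 3 `CCN(CC)CCNC(=O)c1ccc(C(CC)(CC)c2ccc(OCS(C)(=O)=O)c(C)c2)n1CC` carries methylsulfonyl in place of phenylsulfanyl on a saturated chain carbon bound to an oxygen on an aromatic ring. For the measured compounds named here, one measured step bears on this change, a 1.0-fold higher number from compound 1 to compound 2 (0.02 log units; within the scatter) for phenylsulfanyl in place of phenylsulfonyl at that same place, and it lies within the scatter. Going by the values given here, no measured compound shows what removing the aromatic ring from this group does, so that part remains untested. A step of a 1.1-fold higher number from compound 2 to compound 3 (0.05 log units; within the scatter) is therefore expected in this assay with no direction favoured and nothing foreseen beyond the scatter. For compound 3 the estimated value is 5500 nM with 2500 nM to 12000 nM as the expected range.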

Compound 3, half-maximal inhibitory concentration: 14700 nM
Beside the measured number, compound 3's estimate is 2.7-fold (0.43 log units) below it; the whole stated range lies below it.
By their numbers in this assay, from the lowest: compounds 1 and 2 (each within the scatter of the next); then compound 3.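

The earlier pair suggested that this position tolerates change, but in this assay the group on the sulfur turns out to matter, with methyl in place of phenyl on a sulfonyl sulfur giving a 3.1-fold higher number from compound 1 to compound 3 (0.50 log units; beyond the scatter). Going from phenylsulfanyl to methylsulfonyl gives much the same result, a 3.0-fold higher number from compound 2 to compound 3 (0.48 log units; beyond the scatter), so among these three compounds, the two that carry a phenyl ring on the sulfur stand together and the one with methyl shows weaker inhibition. Nothing available explains why the loss of the ring weakens inhibition here.

From the compounds shown here alone, it remains open whether methylsulfanyl would behave like methylsulfonyl, which would show whether the sulfur's oxidation state is still without consequence once the phenyl ring is gone. Going by these compounds, it also remains open whether a cyclohexyl group or a longer chain such as butyl on the sulfonyl sulfur would match phenyl or methyl.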